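Compound 3 to compound 4: a changed side chain

The source may hold more compounds than are shown below. What is called first, only, known or untested is meant among the compounds shown, and "the series" means these compounds.

In an ADME assay on microsomes from liver (Rattus norvegicus) for metabolic stability, read by LC-MS, using NADPH, at 37 degrees C (a lower number here means that the compound disappears faster, a higher number that the compound lasts longer), compound 3 `COc1ccc(-c2nc(CN3CCC(C(=O)NCCCN4C[C@H](C)C[C@H](C)C4)CC3)c(C)o2)cc1OC` gives > 0.5 h, which is a limit of the assay and not a number. Two close relatives differ from it only in the aromatic group on the shared core. Compound 1 `Cc1oc(-c2ccccc2Cl)nc1CN1CCC(C(=O)NCCCN2C[C@H](C)C[C@H](C)C2)CC1`, with 2-chlorophenyl, gives 0.25 h. Compound 2 `Cc1oc(-c2ccc(F)cc2)nc1CN1CCC(C(=O)NCCCN2C[C@H](C)C[C@H](C)C2)CC1`, with 4-fluorophenyl, gives 0.468 h. Between these three, the measured steps are a 1.9-fold higher number from compound 1 to compound 2 (0.27 log units; within the scatter), an at least 2.0-fold higher number from compound 1 to compound 3 (0.30 log units; that floor lies within the scatter) and an at least 1.0-fold higher number from compound 2 to compound 3 (0.02 log units; that floor lies within the scatter).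

Compound 4 `CCN(CC)CCCCNC(=O)C1CCN(Cc2nc(-c3ccc(OC)c(OC)c3)oc2C)CC1` keeps the 3,4-dimethoxyphenyl group of compound 3 but differs elsewhere: (diethylamino)methyl in place of 3,5-dimethylpiperidin-1-yl on a saturated chain carbon, three bonds along the chain from an amide-type nitrogen. Put simply, (diethylamino)methyl stands in place of 3,5-dimethylpiperidin-1-yl on a saturated chain carbon, three bonds along the chain from an amide-type nitrogen. The whole side group thus goes from 3-(3,5-dimethylpiperidin-1-yl)propyl to 4-(diethylamino)butyl.

All three measured steps concern the aromatic group, so none of them tests this change directly. For the measured compounds named here, they offer only a general picture of a series in which no measured step goes beyond the scatter. With no direct evidence for a shift in either direction, no step beyond the scatter is expected in this assay. The expected step is a number no higher from compound 3 to compound 4 (the limit leaves the size open). Compound 4 is estimated at 0.5 h, with an expected range of 0.25 h to 1 h.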

Compound 4, half-life: > 0.5 h
Compound 4: no number, only a limit; the forecaster's own chance of this, stated with the estimate: 40%; the middle value sits exactly at the limit.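

In this assay, compound 3 and compound 4 both stand at a limit of the assay and not at a number, so no step between them can be read: the limit of > 0.5 h in this assay, at which 2 of the 4 values shown sit.

The compounds shown leave open the actual half-life of compound 3 and of compound 4, and so whether 4-(diethylamino)butyl in place of 3-(3,5-dimethylpiperidin-1-yl)propyl changes it at all.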